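From 2-bromobenzyl to 4-(trifluoromethyl)benzyl in the series

The source may report more compounds than this note shows. Statements on the series, on what has been measured and on what is new or still open speak of the compounds shown alone.

In a functional assay on HCT-116 cells (Homo sapiens) for antiproliferative activity, read by MTT assay, with a stated time of 24 h (a higher number here means a weaker inhibitor, a lower number a stronger inhibitor), compound 1 `COc1cc(OC)c(-c2coc3cc(OCC=C(C)C)ccc3c2=O)cc1OC` gives 680 nM, compound 2 `COc1cc(OC)c(-c2coc3cc(OCc4ccccc4)ccc3c2=O)cc1OC` gives 2280 nM, and compound 3 `COc1cc(OC)c(-c2coc3cc(OCc4ccccc4Br)ccc3c2=O)cc1OC` gives 4550 nM. Compound 3 therefore sits level with compound 2 within the scatter, and well apart from compound 1.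

Compound 4 `COc1cc(OC)c(-c2coc3cc(OCc4ccc(C(F)(F)F)cc4)ccc3c2=O)cc1OC` carries 4-(trifluoromethyl)phenyl in place of 2-bromophenyl on a saturated chain carbon bound to an oxygen on an aromatic ring. Going by the values given here, the closest evidence is a 2.0-fold higher number from compound 2 to compound 3 (0.30 log units; within the scatter), the only measured change made on the phenyl ring itself. The larger steps, a 3.4-fold higher number from compound 1 to compound 2 (0.53 log units; beyond the scatter) and a 6.7-fold higher number from compound 1 to compound 3 (0.83 log units; beyond the scatter), both remove 2-methylprop-1-en-1-yl, a change that compound 4 does not repeat. Among the compounds with values here, no measured compound carries trifluoromethyl, so the evidence is indirect.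

No step beyond the scatter is expected in this assay. The estimated step is a 1.5-fold lower number from compound 3 to compound 4 (0.18 log units; within the scatter). For compound 4 the estimated value is 3000 nM, with an expected range of 1200 nM to 7000 nM.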

Compound 4, half-maximal inhibitory concentration: 2440 nM
Compound 4: the middle estimate sits 1.2-fold (0.09 log units) above what was measured; the range from low to high includes it.
By their numbers in this assay, from the lowest: compound 1; then compounds 2, 4 and 3 (each within the scatter of the next).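

Trifluoromethyl on the phenyl ring gives the same reading as bromo in this assay: set against the unsubstituted ring, it stays within the scatter (a 1.1-fold higher number from compound 2 to compound 4 (0.03 log units; within the scatter)), and the two substituted rings also fall within the scatter of each other (a 1.9-fold lower number from compound 3 to compound 4 (0.27 log units; within the scatter)). Two differently substituted rings, 2-bromophenyl and 4-(trifluoromethyl)phenyl, therefore do not separate from phenyl here, while the gap to the 2-methylprop-1-en-1-yl group of compound 1 remains beyond the scatter (a 3.6-fold higher number from compound 1 to compound 4 (0.55 log units; beyond the scatter)). No measured evidence on this result is available to explain it.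

On these data alone, whether an amine or a carboxylic acid on the phenyl ring would break away from compounds 2, 3 and 4 remains open. Also open, as far as these compounds go, is whether a longer chain in place of 2-methylprop-1-en-1-yl would hold, widen or close the gap.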